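A few compounds are considered here, and "the series" means these few. Any claim that something is new, unique, unknown or untested is made for them only; others in the source may bear on it.

Measured so far in a functional assay on MOLT-4 cells (Homo sapiens), with a stated time of 72 h; a higher number here means a weaker inhibitor, a lower number a stronger inhibitor: compound 1 `O=C1Nc2ccc(Br)cc2/C1=N/NC(=S)Nc1ccc(Cl)cc1` gives 29000 nM; compound 2 `Cc1ccc(NC(=S)N/N=C2\C(=O)Nc3ccc(Br)cc32)cc1` gives 4900 nM; compound 3 `Cc1ccc(NC(=S)N/N=C2\C(=O)N(Cc3ccc(Cl)cc3)c3ccc(Br)cc32)cc1` gives 288000 nM.

From compound 1 to compound 2 the change is methyl in place of chloro on an aromatic carbon and the step is a 5.9-fold lower number from compound 1 to compound 2 (0.77 log units; beyond the scatter). From compound 2 to compound 3 the change is 4-chlorobenzyl in place of hydrogen on the amide-type ring nitrogen, with a 59-fold higher number from compound 2 to compound 3 (1.77 log units; beyond the scatter); compound 3 thus stands highest of the three. The difference between the cores of compound 1 and compound 3 is not broken down here.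

Compound 4 `Cc1ccc(CN2C(=O)/C(=N\NC(=S)Nc3ccc(C)cc3)c3cc(Br)ccc32)cc1` is not yet measured. It differs from compound 3 by methyl in place of chloro on an aromatic carbon, the same change as from compound 1 to compound 2, though read one bond further out it is 4-chlorobenzyl to 4-methylbenzyl rather than 4-chlorophenyl to 4-methylphenyl. A step of the same direction but smaller size is expected, a 1.9-fold lower number from compound 3 to compound 4 (0.28 log units; within the scatter), because the earlier case rests on a single pair, a 5.9-fold lower number from compound 1 to compound 2 (0.77 log units; beyond the scatter), made on a different part of the molecule. In this assay compound 4 is expected at about 150000 nM, between 50000 nM and 400000 nM.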

Compound 4, half-maximal inhibitory concentration: 393000 nM
Compound 4: middle estimate off by 2.6-fold (0.42 log units), on the low side; low and high end bracket the measured number.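

Methyl in place of chloro does not carry over unchanged from one core to the other in this assay: the same change on two cores in this assay, a 5.9-fold lower number (0.77 log units; beyond the scatter) from compound 1 to compound 2 and a 1.4-fold higher number (0.14 log units; within the scatter) from compound 3 to compound 4, 8.1-fold (0.91 log units) apart, beyond the scatter of two such steps. The new step is a 1.4-fold higher number from compound 3 to compound 4 (0.14 log units; within the scatter), made on the 4-chlorobenzyl group rather than the 4-chlorophenyl group, so a single pair on each core cannot separate the role of the core from that of the ring carrying the change. The large step of an 80-fold higher number from compound 2 to compound 4 (1.90 log units; beyond the scatter) shows that 4-methylbenzyl on the amide-type nitrogen goes with a much higher number, as 4-chlorobenzyl does in compound 3.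

Going by these compounds, it remains open whether a benzyl group carrying an amine or a carboxylic acid would bring the number back towards that of compound 2, at 4900 nM. Also open, on these data alone, is whether methyl in place of chloro on the 4-chlorophenyl group would give the earlier step with a benzyl group on that nitrogen.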